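A few compounds are considered here, and "the series" means these few. Any claim that something is new, unique, unknown or untested is made for them only; others in the source may bear on it.

Series notes. Compound 1 `COc1cc(-c2cc(/C=C/C(=O)c3ccc(Cl)c(Cl)c3)[nH]n2)cc(OC)c1OC`, compound 2 `COc1ccc(-c2cc(/C=C/C(=O)c3ccc(N)cc3)[nH]n2)cc1OC` and compound 3 `COc1ccc(-c2cc(/C=C/C(=O)c3cc(OC)c(OC)c(OC)c3)[nH]n2)cc1OC` share one core and differ in the groups on either side of it. In a functional assay on OVCAR-8 cells (Homo sapiens) for cytotoxicity, read by sulforhodamine B assay, with a stated time of 48 h, tested at 0.1 uM (on this read-out lower numbers stand for a stronger effect and higher numbers for a weaker effect at the one concentration tested), compound 1 gives 97%, compound 2 gives 99% and compound 3 gives 100%. Compound 1 holds the lowest of the three numbers, but both other values lie within the usual scatter of it, so the three read as one cluster at this concentration. Compound 4 `COc1cc(-c2cc(/C=C/C(=O)c3ccc(F)c(F)c3)[nH]n2)cc(OC)c1OC` has not been measured; it differs from compound 1 in one place: 3,4-difluorophenyl in place of 3,4-dichlorophenyl on a carbonyl carbon. Nothing measured here tracks this change. For compound 4 the step of a number 1 percentage points higher from compound 1 to compound 4 (within the scatter) is expected to stay within the scatter, in no particular direction. The estimate for compound 4 in this assay is 98%, with a range from 88% to 106%.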

Compound 4, a percentage reported as activity, at one concentration (the size of the read-out at that concentration, not a potency): 96%
Beside the measured number, compound 4's estimate is 2 percentage points above it, and the stated range covers the measured number.
By their numbers in this assay, from the lowest: compounds 4, 1, 2 and 3 (each within the scatter of the next).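

In this assay, within the data shown here, the only single-place step, a number 1 percentage points lower from compound 1 to compound 4 (within the scatter), gives the first direct reading at this position: 3,4-difluorophenyl in place of 3,4-dichlorophenyl on a carbonyl carbon leaves the number inside the scatter. Exchanging one dihalophenyl for the other therefore does not separate compound 4 from compound 1 at this concentration. No other data bear on this result. Still open, on these data alone, is whether a carboxylic acid or a longer alkyl chain at this position would move the number beyond the scatter.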